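The source may report more compounds than this note shows. Statements on the series, on what has been measured and on what is new or still open speak of the compounds shown alone.

This account follows a single change on a shared core, read in a physicochemical assay for lipophilicity, at pH 7.4; a lower number here means a more polar compound, a higher number a more lipophilic compound. Compound 1 `Cc1cc(C(=O)NCc2ccccn2)nn1Cc1cc(Cl)ccc1OCc1ccccc1` gives > 3.7, and this figure is a limit of the assay, not a number. Compound 3 `Cc1cc(NC(=O)C2CCCO2)nn1Cc1cc(Cl)ccc1OCc1ccccc1` departs from compound 1 in one place: ((oxolan-2-yl)carbonyl)amino in place of ((pyridin-2-yl)methyl)carbamoyl on an aromatic carbon. On an aromatic carbon of a five-membered aromatic ring with 2 nitrogen, ((oxolan-2-yl)carbonyl)amino stands in place of ((pyridin-2-yl)methyl)carbamoyl. For the measured compounds named here, no measured pair shows this exchange on its own, so the size of the step in this assay can only be judged loosely. A shift beyond the usual scatter is not expected, and the estimated step of a number at least 0.10 log units lower from compound 1 to compound 3 (that floor lies within the scatter) stays within it. Going by the values given here, the only true number available to anchor the lower side of this expectation is that of compound 2 `Cc1cc(C(N)=O)nn1Cc1cc(Cl)ccc1OCC(C)C`, at 3.1. Compound 3 is expected at 3.6, with an estimated range from 3.1 to 4.1.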

Compound 3, distribution coefficient: > 3.7
Compound 3 gave a limit, no number; the forecaster's own chance of this, stated with the estimate: 40%; middle value at least 0.10 log units away from the limit.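

For the compounds shown here, compound 1 and compound 3 each give only a limit of the assay, not a number, so no step between them can be read. The compounds shown leave open whether, how far and in which direction ((oxolan-2-yl)carbonyl)amino in place of ((pyridin-2-yl)methyl)carbamoyl shifts the distribution coefficient on the shared core.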